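From a 4-Methylbenzyl to a 3-Methoxybenzyl Group

The source may hold more compounds than are shown below. What is called first, only, known or untested is meant among the compounds shown, and "the series" means these compounds.

Three measured compounds share one core and differ in the group on its amide-type nitrogen. In a functional assay on HepG2 cells (Homo sapiens) for antiproliferative activity, read by MTT assay, with a stated time of 48 h (on this read-out lower numbers stand for stronger inhibition and higher numbers for weaker inhibition), compound 1 `COc1ccc(-c2ccc3c(c2)C(=O)C(=O)N3c2ccc(OC)cc2)cc1` reports only a limit, > 10000 nM. Compound 2 `COc1ccc(-c2ccc3c(c2)C(=O)C(=O)N3Cc2ccc(F)cc2)cc1` gives 1120 nM. Compound 3 `COc1ccc(-c2ccc3c(c2)C(=O)C(=O)N3Cc2ccc(C)cc2)cc1` gives 330 nM, the lowest number of the three. Replacing the 4-methoxyphenyl group produced the two larger changes: an at least 8.9-fold lower number from compound 1 to compound 2 (0.95 log units; beyond the scatter) and an at least 30-fold lower number from compound 1 to compound 3 (1.48 log units; beyond the scatter).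

Compound 4 `COc1ccc(-c2ccc3c(c2)C(=O)C(=O)N3Cc2cccc(OC)c2)cc1` has 3-methoxyphenyl in place of 4-methylphenyl on a saturated chain carbon bound to an amide-type nitrogen in a ring. Its benzyl link stays, so the large steps away from compound 1 offer little guidance. The closest comparison is the modest change between two substituted benzyl compounds, a 3.4-fold lower number from compound 2 to compound 3 (0.53 log units; beyond the scatter). That suggests a modest step, and with compound 3 lowest so far, a higher number seems more likely. The expected change is a 1.8-fold higher number from compound 3 to compound 4 (0.26 log units; within the scatter). In this assay, compound 4 is expected at 600 nM, with an estimated range of 180 nM to 2000 nM.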

Compound 4, half-maximal inhibitory concentration: 700 nM
Estimate against measurement, compound 4: 1.2-fold (0.07 log units) below; low and high end bracket the measured number.
By their numbers in this assay, from the lowest: compound 3; then compounds 4 and 2 (each within the scatter of the next). At a limit, above all of these: compound 1.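

Going from the 4-methylbenzyl group to the 3-methoxybenzyl group gives a 2.1-fold higher number from compound 3 to compound 4 (0.33 log units; beyond the scatter) in this assay, so this position responds to a change in both the substituent and its place on the benzyl ring. The 3-methoxybenzyl and 4-fluorobenzyl groups, by contrast, cannot be told apart here, with a 1.6-fold lower number from compound 2 to compound 4 (0.20 log units; within the scatter). A third benzyl compound now stands well clear of the limit reported for compound 1, but a limit fixes only a bound on the size of an at least 14-fold lower number from compound 1 to compound 4 (1.15 log units; beyond the scatter): the limit of > 10000 nM in this assay, at which 1 of the 4 values shown sits.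

Compound 3 and compound 4 differ in both the substituent and its place, so the shown compounds cannot separate those two changes; a 4-methoxybenzyl or 3-methylbenzyl group would do so. Going by these compounds, how an amine or a carboxylic acid on the benzyl ring, or a longer chain in place of the benzyl link, would fare also remains open.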